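The compounds below may be only part of what the source reports. "The series", "measured", "known", "first", "only" and "open" are said of these compounds alone.

For the measured compounds named here, in a functional assay on HEK293 cells for positive allosteric modulation of metabotropic glutamate receptor 5 (Rattus norvegicus), read by fluorescence and calcium flux (a lower number here means a smaller maximal response, a higher number a larger maximal response), compound 1 `C[C@@H](NC(=O)c1ccc(C#Cc2ccc(F)cc2)cn1)C(C)(C)O` gives 66.2%, and compound 2 `C[C@@H](NC(=O)c1ccc(C#Cc2cccnc2)cn1)C(C)(C)O` gives 71.5%; of these two numbers the one for compound 2 is the higher, with compound 1 its nearest neighbour. Going by the values given here, the one step measured so far, a number 5.3 percentage points higher from compound 1 to compound 2 (within the scatter), stayed within the scatter. Compound 3 `Cc1nc(C#Cc2ccc(C(=O)N[C@H](C)C(C)(C)O)nc2)cs1` differs from compound 2 in one place: 2-methyl-1,3-thiazol-4-yl in place of pyridin-3-yl on a triple-bonded carbon. Among the compounds with values here, that earlier step bears on this one insofar as it also exchanged the ring on a triple-bonded carbon and produced no change beyond the scatter, but no measured pair covers the entry of a 2-methyl-1,3-thiazol-4-yl, so the expectation rests on a single step. On that basis the expected step is a number 1.5 percentage points lower from compound 2 to compound 3 (within the scatter), with no change beyond the scatter. Compound 3 is therefore estimated at 70%, with a range from 55% to 85%.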

Compound 3, largest response reached (reported as efficacy), in percent of the reference or control that the assay uses: 66.6%
Beside the measured number, compound 3's estimate is 3.4 percentage points above it, and the stated range covers the measured number.
By their numbers in this assay, from the lowest: compounds 1, 3 and 2 (each within the scatter of the next).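

In this assay, the result extends what the earlier pair showed to a ring of another size: a five-membered aromatic ring with 2 hetero atoms on the triple-bonded carbon gives a number 4.9 percentage points lower from compound 2 to compound 3 (within the scatter) and a number 0.4 percentage points higher from compound 1 to compound 3 (within the scatter). Among these three compounds, neither the ring size nor the sulfur of 2-methyl-1,3-thiazol-4-yl separates the maximal responses beyond the scatter, and the three aromatic rings cannot be ranked at this place. Nothing available accounts for this shared level of response.

Going by these compounds, what an amine, a carboxylic acid or a longer alkyl chain would do on the triple-bonded carbon remains open, as does whether any group at this place can shift the response beyond the scatter. On these data alone, the contribution of the shared core also remains open, since it is the same in all three compounds.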